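Ester versus acid at the urea-linked carboxylic group

The source may hold more compounds than are shown below. What is called first, only, known or untested is meant among the compounds shown, and "the series" means these compounds.

Compound 1 `Cc1cc(C(=O)N2CCCCc3ccccc32)ccc1CNC(=O)NCC(=O)O` gives 180 nM in a functional assay on HEK293 cells for agonist activity at Vasopressin V2 receptor (Homo sapiens), read by a luciferase reporter and cAMP accumulation; a higher number here means that more compound is needed for the effect, a lower number that less compound is needed. Compound 2 `COC(=O)CNC(=O)NCc1ccc(C(=O)N2CCCCc3ccccc32)cc1C` differs from compound 1 by methyl in place of hydrogen on an oxygen next to a carbonyl group. In this assay compound 2 gives 37 nM; the step is a 4.9-fold lower number from compound 1 to compound 2 (0.69 log units; beyond the scatter). Compound 3 `Cc1cc(C(=O)N2CCCCc3ccccc32)ccc1CNC(=O)N1CCC[C@H]1C(=O)O` carries a changed core, (2-carboxypyrrolidin-1-yl in place of (carboxymethyl)amino on a carbonyl carbon), and gives 680 nM in this assay, a step of a 3.8-fold higher number from compound 1 to compound 3 (0.58 log units; beyond the scatter) and of an 18-fold higher number from compound 2 to compound 3 (1.26 log units; beyond the scatter). Compound 4 `COC(=O)[C@@H]1CCCN1C(=O)NCc1ccc(C(=O)N2CCCCc3ccccc32)cc1C` differs from compound 3 by methyl in place of hydrogen on an oxygen next to a carbonyl group, the same change as that between compound 1 and compound 2, at the same place. Compound 4 is not yet measured in this assay. For the measured compounds named here, the expected step is a 4.5-fold lower number from compound 3 to compound 4 (0.66 log units; beyond the scatter), resting on the single earlier instance a 4.9-fold lower number from compound 1 to compound 2 (0.69 log units; beyond the scatter). Compound 4 is therefore estimated at 150 nM, between 50 nM and 500 nM.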

Compound 4, half-maximal effective concentration: 100 nM
The estimate for compound 4 lay 1.5-fold (0.18 log units) above the measured number; measured number inside the range.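

In this assay the change from carboxy to methoxycarbonyl carries over from one core to the other, the new step matching the earlier one: the same change on two cores in this assay, a 4.9-fold lower number (0.69 log units; beyond the scatter) from compound 1 to compound 2 and a 6.8-fold lower number (0.83 log units; beyond the scatter) from compound 3 to compound 4, 1.4-fold (0.15 log units) apart, within the scatter of two such steps. The 2-(methoxycarbonyl)pyrrolidin-1-yl group gives a 2.7-fold higher number from compound 2 to compound 4 (0.43 log units; beyond the scatter) against the ester on the core of compound 1, so the difference between the two esters remains, while a 1.8-fold lower number from compound 1 to compound 4 (0.26 log units; within the scatter) places the ester of one core and the acid of the other within the scatter of each other. With a 6.8-fold lower number from compound 3 to compound 4 (0.83 log units; beyond the scatter) as the second instance, the agreement rests on two cores only and does not show that the step holds on any further core. From the compounds shown here alone, an ethyl ester or a primary amide in place of the methyl ester remains open. So does a longer chain on the carbonyl carbon.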